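The source may hold more compounds than are shown below. What is called first, only, known or untested is meant among the compounds shown, and "the series" means these compounds.

Compound 1 `CCCOC(=O)C1=C(C)NC(=S)NC1c1ccco1` was tested in an assay on membranes from HeLa cells for displacement of a labelled ligand from adenosine receptor A3 (Homo sapiens), read by scintillation counting, with a stated time of 180 min, tested at 1 uM (on this read-out higher numbers stand for more inhibition at the one concentration tested (going by the name of the read-out) and lower numbers for less inhibition), where compound 1 gives 1%. Compound 2 `CCCOC(=O)C1=C(C)NC(=S)NC1c1ccoc1` shows (furan-3-yl in place of furan-2-yl on a saturated ring carbon), and in this assay compound 2 gives 3%, so this change gave a number 2 percentage points higher from compound 1 to compound 2 (within the scatter). Compound 3 `COC(=O)C1=C(C)N(C)C(=O)NC1c1ccco1` has a different core from compound 1; the difference between the two cores is not broken down here. In this assay compound 3 gives 9%. Compound 4 `COC(=O)C1=C(C)N(C)C(=O)NC1c1ccoc1` has not yet been measured and differs from compound 3 by furan-3-yl in place of furan-2-yl on a saturated ring carbon, the same kind of change, though here the saturated ring carbon is next to the ring atom that bears a methoxycarbonyl group instead of a propoxycarbonyl group and is also three ring bonds from the ring atom that bears a methyl group. Because the earlier step of a number 2 percentage points higher from compound 1 to compound 2 (within the scatter) stayed within the scatter, the expected step is a number 2 percentage points higher from compound 3 to compound 4 (within the scatter). Compound 4 is therefore estimated at 11%, expected to fall between 0% and 24%.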

Compound 4, a percentage reported as inhibition, at one concentration (the size of the read-out at that concentration, not a potency): 7%
Compound 4: the middle estimate sits 4 percentage points above what was measured; the measured number falls inside the stated range.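

In this assay, furan-3-yl in place of furan-2-yl on the core of compound 3 gave a number 2 percentage points lower from compound 3 to compound 4 (within the scatter). Set beside the earlier step, the change behaves no differently on the two cores: the same change on two cores in this assay, a number 2 percentage points higher (within the scatter) from compound 1 to compound 2 and a number 2 percentage points lower (within the scatter) from compound 3 to compound 4, 4 percentage points apart, within the scatter of two such steps This shows only that the swap leaves the number within the scatter on both cores; with so little inhibition at the one concentration tested, it does not show that the change would carry over the same way to a core or compound with a larger reading.

The compounds shown leave open what a phenyl ring in place of the furan would do on that saturated ring carbon. Also open, on these data alone, is what a carboxylic acid or an amide in place of the ester would give in this assay.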